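Amino for hydroxy in a benzophenone

This account rests on a few compounds, and the source may have more. Where it says the series, first, only, none or still open, it means among the compounds named here.

Compound 1 `COc1ccc(C(=O)c2ccc(OC)c(O)c2OC)cc1` gave no result in a functional assay on HT-29 cells (Homo sapiens) for cytotoxicity, read by sulforhodamine B assay, with a stated time of 48 h (on this read-out higher numbers stand for weaker inhibition of growth and lower numbers for stronger inhibition of growth), and for compound 1 the entry reads "not determined" (no result reported). Among the compounds with values here, compound 2 `COc1ccc(C(=O)c2cc(OC)c(OC)c(OC)c2)c(OC)c1O` is the only compound with a number on this assay, giving 3460 nM, so it stands alone as the reference point. Compound 3 `COc1ccc(C(=O)c2cc(OC)c(OC)c(OC)c2)c(OC)c1N` differs from it by a single change: amino in place of hydroxy on an aromatic carbon. Within the data shown here, with no measured pair of this kind to lean on, the step is expected to be modest and towards stronger inhibition of growth, though it may fall within the scatter, so a 1.7-fold lower number from compound 2 to compound 3 (0.24 log units; within the scatter) is the estimate. Compound 3 is expected at 2000 nM, within 600 nM to 7000 nM.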

Compound 3, concentration for 50% growth inhibition: 32.3 nM
For compound 3 the middle estimate is 62-fold (1.79 log units) above the measured one; the measured number lies below the stated range.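

On this assay, amino in place of hydroxy on this aromatic carbon, ortho to two methoxy groups, gives a 110-fold lower number from compound 2 to compound 3 (2.03 log units; beyond the scatter) and thus shows that this position is highly sensitive to the group it carries. The size of the step stands out, as the two groups match in heavy-atom count and in hydrogen-bond donors and acceptors. Nothing shown here accounts for it. Going by these compounds, whether a methylamino group, an acetamide or a plain hydrogen on this carbon would keep the stronger inhibition of growth remains open. So does whether the same exchange at another position on the shared core would give a step of this size.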